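This account rests on a few compounds, and the source may have more. Where it says the series, first, only, none or still open, it means among the compounds named here.

In an ADME assay on MRC5 cells (Homo sapiens) for inhibition, with a stated time of 72 h (on this read-out higher numbers stand for an effect only at larger amounts of compound and lower numbers for an effect already at smaller amounts), compound 2 `COc1cccc(OC)c1C(=O)Nc1c[nH]nc1C(=O)NC1CC1` reaches only a limit, > 50000 nM. Compound 1 `CO[C@H]1CC[C@H](NC(=O)c2n[nH]cc2NC(=O)c2ccc(N3CCCC3)cc2)CC1` likewise gives only a limit in this assay, > 50000 nM. Among the measured compounds shown here, compound 3 `CO[C@H]1CC[C@H](NC(=O)c2n[nH]cc2NC(=O)c2ccc(-c3ccccc3)o2)CC1` is the one compound with a number here, giving 100 nM in this assay. Compound 2 thus stands at the limit of > 50000 nM in this assay, at which 2 of the 3 values shown sit. Compound 4 `COc1cccc(OC)c1C(=O)Nc1c[nH]nc1C(=O)NCCCN(C)C` has not been measured in this assay. It differs from compound 2 in one place: 3-(dimethylamino)propyl in place of cyclopropyl on an amide-type nitrogen. For the measured compounds named here, no measured pair shows what this change does in this assay, and compound 3 differs from compound 2 in more than one place. The step of a number no higher from compound 2 to compound 4 (the limit leaves the size open) is therefore expected to be none beyond the scatter, with compound 4 most likely again at a limit. Compound 4 is estimated at 50000 nM, within 20000 nM to 120000 nM.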

Compound 4, half-maximal effective concentration: > 50000 nM
Compound 4 ended at the assay's limit; the forecaster's own chance of this, stated with the estimate: 70%; the middle value sits exactly at the limit.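

Compound 2 and compound 4 both stand at a limit in this assay, so no step can be read between them. The compounds shown leave open what 3-(dimethylamino)propyl in place of cyclopropyl on an amide-type nitrogen does in this assay.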